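Chloro for methoxy on the pendant aryl of compound 2

The source may hold more compounds than are shown below. What is called first, only, known or untested is meant among the compounds shown, and "the series" means these compounds.

Measured compounds:
compound 1 `Fc1cc(Nc2cc(Nc3ccc(Cl)cc3)ncn2)ccc1Oc1ccncc1-c1cccnc1`, 240 nM
compound 2 `COc1ccc(-n2nc(C(=O)Nc3ccc(Oc4ccncc4-c4cccnc4)c(F)c3)c3ccccc3c2=O)cc1`, 740 nM

In a functional assay on MKN-45 cells (Homo sapiens) for cytotoxicity, read by MTT assay, with a stated time of 72 h (on this read-out lower numbers stand for stronger inhibition and higher numbers for weaker inhibition), compound 2 gives 740 nM, the higher of the two numbers measured; compound 1 gives 240 nM, and the gap between them lies beyond the scatter. Compound 3 `O=C(Nc1ccc(Oc2ccncc2-c2cccnc2)c(F)c1)c1nn(-c2ccc(Cl)cc2)c(=O)c2ccccc12` has not yet been measured. It differs from compound 2 in one place: chloro in place of methoxy on an aromatic carbon, so that the 4-methoxyphenyl of compound 2 becomes a 4-chlorophenyl in compound 3. Going by the values given here, no step between measured compounds shows what such an exchange does in this assay, and compound 1 carries a different core, so its value only tells where the series reaches. The step is expected to be small and within the usual scatter in either direction, so the number for compound 3 is estimated close to that of compound 2, as a 1.1-fold lower number from compound 2 to compound 3 (0.06 log units; within the scatter). Compound 3 is expected to give about 650 nM in this assay, between 220 nM and 2000 nM.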

Compound 3, half-maximal inhibitory concentration: 430 nM
Estimate against measurement, compound 3: 1.5-fold (0.18 log units) above; the range from low to high includes it.
By their numbers in this assay, from the lowest: compounds 1, 3 and 2 (each within the scatter of the next, the first and the last beyond it).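

In this assay, going by these compounds alone, the exchange of the 4-methoxyphenyl for a 4-chlorophenyl gives a 1.7-fold lower number from compound 2 to compound 3 (0.24 log units; within the scatter), the first reading of any change at this position, on an aromatic carbon para to a large group. For this one pair, the methoxy can leave and the chloro can enter without a difference that stands out from the scatter, so the two groups cannot be told apart here. No measured property of these groups bears on this result.

As far as these compounds go, whether an amine, a carboxylic acid or a longer chain such as butoxy at the same position would also stay within the scatter of compound 2 remains open. So does whether methoxy in place of chloro on the 4-chlorophenyl of compound 1 would give a step of similar size on that different core.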